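A few compounds are considered here, and "the series" means these few. Any claim that something is new, unique, unknown or untested is made for them only; others in the source may bear on it.

Compound 1 `CN1CCN(CCCOc2cccc3nc(Nc4ccc(Cl)c(C(F)(F)F)c4)ccc23)CC1`: 1810 nM
Compound 2 `CC(C)c1ccc(Nc2ccc3c(OCCCN4CCN(C)CC4)cccc3n2)cc1`: 14400 nM
Compound 3 `CN1CCN(CCCOc2cccc3nc(Nc4cc(Cl)cc(Cl)c4)ccc23)CC1`: 1680 nM

These three compounds share one core and differ only in the aromatic group attached to the nitrogen on the aromatic ring. In a functional assay on OVCAR-3 cells (Homo sapiens) for inhibition, read by sulforhodamine B assay, with a stated time of 48 h (a lower number here means a stronger inhibitor of growth, a higher number a weaker inhibitor of growth), compound 3 gives the lowest number of the three, but its nearest neighbour is compound 1 at a 1.1-fold lower number from compound 1 to compound 3 (0.03 log units; within the scatter), so the two cannot be told apart. Compound 2, by contrast, stands well apart: an 8.6-fold lower number from compound 2 to compound 3 (0.93 log units; beyond the scatter).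

Compound 4 `CN1CCN(CCCOc2cccc3nc(Nc4cccc(Cl)c4)ccc23)CC1` takes compound 3 one step further: hydrogen in place of chloro on an aromatic carbon. Going by the values given here, no measured pair shows exactly this change, removing one chloro group while the other remains. What the measured steps do show is that the two halogen-bearing groups of compound 1 and compound 3 behave alike, while the step to the 4-isopropylphenyl group of compound 2, an 8.0-fold higher number from compound 1 to compound 2 (0.90 log units; beyond the scatter), weakens growth inhibition clearly. Losing one chloro group is a smaller change than either of those, so in this assay a mild weakening at most is expected, a 2.1-fold higher number from compound 3 to compound 4 (0.32 log units; beyond the scatter). Compound 4 is therefore estimated at 3500 nM, with a likely range from 1500 nM to 9000 nM.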

Compound 4, concentration for 50% growth inhibition: 1450 nM
The estimate for compound 4 lay 2.4-fold (0.38 log units) above the measured number; the whole stated range lies above it.
By their numbers in this assay, from the lowest: compounds 4, 3 and 1 (each within the scatter of the next); then compound 2.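

In this assay, taking one chloro group off the 3,5-dichlorophenyl group leaves no change that can be told from the usual scatter (a 1.2-fold lower number from compound 3 to compound 4 (0.06 log units; within the scatter)), so a second chloro group on this ring makes no detectable difference to growth inhibition in these cells. The 3-chlorophenyl group also cannot be told apart from the 4-chloro-3-(trifluoromethyl)phenyl group (a 1.2-fold lower number from compound 1 to compound 4 (0.10 log units; within the scatter)), which means that this position tolerates all three chlorine-bearing groups tested, with or without the extra trifluoromethyl or chloro group. The 4-isopropylphenyl group remains the only one that stands apart, and the single chloro group of the 3-chlorophenyl group is enough to show that gap (a 9.9-fold lower number from compound 2 to compound 4 (1.00 log units; beyond the scatter)), so among these four compounds the one without a chloro group is the outlier.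

Nothing measured here explains why one chloro group serves as well as two, or why the 4-isopropylphenyl group differs. As far as these compounds go, it also remains open whether the last chloro group matters at all, a question that a plain phenyl group, or a fluoro, methoxy or nitrile group in its place, would answer.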